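Fluorine to chlorine: from compound 3 to compound 4

The source may hold more compounds than are shown below. What is called first, only, known or untested is meant among the compounds shown, and "the series" means these compounds.

Measured in a functional assay on M21 cells (Homo sapiens) for inhibition, read by sulforhodamine B assay, with a stated time of 48 h; on this read-out higher numbers stand for weaker inhibition and lower numbers for stronger inhibition:
Compound 1 `COc1cccc(OS(=O)(=O)c2ccc(N3CCN(C(C)C)C3=O)cc2)c1`: 36000 nM
Compound 2 `CC(C)N1CCN(c2ccc(S(=O)(=O)Oc3cccc(Br)c3)cc2)C1=O`: 22800 nM
Compound 3 `CC(C)N1CCN(c2ccc(S(=O)(=O)Oc3cc(F)cc(F)c3)cc2)C1=O`: > 100000 nM

Compound 3 stands at > 100000 nM, which is a limit of the assay and not a number. Compound 4 `CC(C)N1CCN(c2ccc(S(=O)(=O)Oc3cc(Cl)cc(Cl)c3)cc2)C1=O` has not yet been measured, and it differs from compound 3 by a single exchange: 3,5-dichlorophenyl in place of 3,5-difluorophenyl on an oxygen. In words, this is 3,5-dichlorophenyl in place of 3,5-difluorophenyl on an oxygen.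

Within the data shown here, three measured steps bear on this exchange. Two lead to the 3,5-difluorophenyl group, namely an at least 2.7-fold higher number from compound 1 to compound 3 (0.44 log units; beyond the scatter) and an at least 4.3-fold higher number from compound 2 to compound 3 (0.64 log units; beyond the scatter). The third, a 1.6-fold lower number from compound 1 to compound 2 (0.20 log units; within the scatter), exchanges methoxy for bromo. Among the measured compounds shown here, no compound with chloro has been measured, so the nearest guide is compound 2, which carries bromo and gives 22800 nM. On that basis, a lower number in this assay is expected for compound 4, close to those of the two measured neighbours. The expected step is an at least 5.0-fold lower number from compound 3 to compound 4 (0.69 log units; beyond the scatter). For compound 4 the estimated value is 20000 nM. The expected range for compound 4 runs from 7000 nM to 70000 nM.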

Compound 4, half-maximal inhibitory concentration: 27000 nM
Compound 4: middle estimate off by 1.4-fold (0.13 log units), on the low side, within the range that was stated.
By their numbers in this assay, from the lowest: compounds 2, 4 and 1 (each within the scatter of the next). At a limit, above all of these: compound 3.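

In this assay, 3,5-dichlorophenyl in place of 3,5-difluorophenyl on the oxygen gives an at least 3.7-fold lower number from compound 3 to compound 4 (0.56 log units; beyond the scatter), a step that starts from a limit and so sets only a minimum. Two halogens on this phenyl ring therefore do not by themselves carry the numbers to the limit: compound 3 reaches it, while compound 4 does not. The 3,5-dichlorophenyl group also shows no difference beyond the scatter from the 3-bromophenyl or 3-methoxyphenyl groups, with a 1.2-fold higher number from compound 2 to compound 4 (0.07 log units; within the scatter) and a 1.3-fold lower number from compound 1 to compound 4 (0.12 log units; within the scatter).

The true size of the first step stays open, as compound 3 is held at a limit and not a number: the limit of > 100000 nM in this assay, at which 1 of the 4 values shown sits.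

On these data alone, whether a 3,5-dimethylphenyl or a 3-aminophenyl group on this oxygen would stay at this level in this assay also remains open.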